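Amide substituent change in a fluorinated indanylidene acetamide series

The compounds below may be only part of what the source reports. "The series", "measured", "known", "first", "only" and "open" are said of these compounds alone.

Measured compounds:
compound 1 `CCN(C)C(=O)/C=C1\CCc2c(F)cc(F)cc21` — 100%
compound 2 `CNC(=O)/C=C1\CCc2cc(F)c(F)cc21` — 100%
compound 3 `O=C(/C=C1\CCc2ccc(F)cc21)NCC1CC1` — 50%

In a functional assay on the whole organism with Mus musculus as the target, at a dose of 100 mg/kg by the intraperitoneal route (on this read-out higher numbers stand for more inhibition at the one dose given (going by the name of the read-out) and lower numbers for less inhibition), compound 1 gives 100% and compound 2 gives 100%. Compound 3 stands lowest of the three in this assay; its nearest neighbour is compound 1, which lies higher, and compound 2 lies as far away, both gaps beyond the scatter. No pair among these three differs in one place, so no single step is known. Compound 4 `CCNC(=O)/C=C1\CCc2ccc(F)cc21` differs from compound 3 by methyl in place of cyclopropyl on a saturated chain carbon bound to an amide-type nitrogen. Compounds 1 and 2 carry small amide substituents and a different core, so their values give only loose guidance. Compound 4 is expected to show a moderate rise from compound 3, as a number 20 percentage points higher from compound 3 to compound 4 (beyond the scatter), reading an estimated 70% in this assay, within 40% to 100%.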

Compound 4, a percentage reported as inhibition, in the whole organism at one dose (the size of the read-out at that dose, not a potency): 100%
Compound 4: middle estimate off by 30 percentage points, on the low side; measured number inside the range.
By their numbers in this assay, from the lowest: compound 3; then compounds 1, 2 and 4 (each within the scatter of the next).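

In this assay, within the data shown here, methyl in place of cyclopropyl on a saturated chain carbon bound to an amide-type nitrogen gives a number 50 percentage points higher from compound 3 to compound 4 (beyond the scatter) and provides the first single-place reading. With the core of compound 3 held fixed, the amide substituent alone changes the read-out, so the lower value of compound 3 cannot be attributed to that core alone. No measured finding accounts for this step.

As far as these compounds go, it remains open whether a longer chain, such as n-propyl, or a hydroxyethyl group on the amide nitrogen would keep the value of compound 4 . Whether cyclopropyl itself or simply the larger cyclopropylmethyl group lowers the value also remains unresolved.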